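This account rests on a few compounds, and the source may have more. Where it says the series, first, only, none or still open, it means among the compounds named here.

Compound 1 `CCN(CC)S(=O)(=O)c1ccc(S(=O)(=O)N2CCC[C@@H](C(=O)N3CCN(C(=O)OC(C)(C)C)CC3)C2)cc1` gives 70 nM in a functional assay on MIA PaCa-2 cells (Homo sapiens) for inhibition, read by MTT assay, with a stated time of 7 days; a higher number here means a weaker inhibitor, a lower number a stronger inhibitor.
Compound 2 `CCN(CC)S(=O)(=O)c1ccc(S(=O)(=O)N2CCC[C@@H](C(=O)N[C@H]3CCN(C(=O)OC(C)(C)C)C3)C2)cc1` gives 100 nM in this assay.
Compound 3 `CCN(CC)S(=O)(=O)c1ccc(S(=O)(=O)N2CCC[C@@H](c3nc(C)no3)C2)cc1` gives 4100 nM in this assay.

Compound 1 has the lowest of the three numbers. Compound 2 sits within the scatter of compound 1, so the two cannot be ordered; compound 3 lies well beyond the scatter above compound 1.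

Compound 4 `CCN(CC)S(=O)(=O)c1ccc(S(=O)(=O)N2CCC[C@@H](C(=O)N3CCN(c4nc(C(C)C)no4)CC3)C2)cc1` differs from compound 1 in one place: 3-isopropyl-1,2,4-oxadiazol-5-yl in place of tert-butoxycarbonyl on an amine nitrogen in a ring. Within the data shown here, no measured pair shows this exact change, so the step is judged from the change alone. The shared core is kept, and only the group on the ring amine nitrogen is exchanged. The step is expected to be small, a 2.1-fold higher number from compound 1 to compound 4 (0.33 log units; beyond the scatter), towards a somewhat higher number at most. Compound 4 is estimated at 150 nM, with a range from 40 nM to 600 nM.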

Compound 4, half-maximal inhibitory concentration: 50 nM
Estimate against measurement, compound 4: 3.0-fold (0.48 log units) above; low and high end bracket the measured number.
By their numbers in this assay, from the lowest: compounds 4, 1 and 2 (each within the scatter of the next); then compound 3.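

In this assay, 3-isopropyl-1,2,4-oxadiazol-5-yl in place of tert-butoxycarbonyl gives a 1.4-fold lower number from compound 1 to compound 4 (0.15 log units; within the scatter). Thus, on this amine nitrogen in a ring, a group with one five-membered aromatic ring can replace one with no ring, and the number stays within the scatter. No measurement shown here explains this result. As far as these compounds go, it remains open whether the ring amine with only a hydrogen on this nitrogen, or an acetyl group there, would keep the number. Also open, from the compounds shown here alone, is how a longer chain in place of the isopropyl would fare.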